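Carbamoyl added to the pyrrolidin-1-yl amide

This account rests on a few compounds, and the source may have more. Where it says the series, first, only, none or still open, it means among the compounds named here.

In an in vivo functional assay on the whole organism for inhibition, with Rattus norvegicus as the target (on this read-out lower numbers stand for an effect already at smaller amounts and higher numbers for an effect only at larger amounts of compound), compound 1 `CCCCc1nc(C)c(CCC(=O)OCC)c(=O)n1Cc1ccc(-c2ccccc2-c2nnn[nH]2)cc1` gives 0.066 mg/kg, compound 2 `CCCCc1nc(C)c(CC(=O)N(C)C)c(=O)n1Cc1ccc(-c2ccccc2-c2nnn[nH]2)cc1` gives 0.018 mg/kg and compound 3 `CCCCc1nc(C)c(CC(=O)N2CCCC2)c(=O)n1Cc1ccc(-c2ccccc2-c2nnn[nH]2)cc1` gives 0.056 mg/kg. Compound 3 holds the second highest of the three numbers. Its gaps to the other two are a 1.2-fold lower number from compound 1 to compound 3 (0.07 log units; within the scatter) and a 3.1-fold higher number from compound 2 to compound 3 (0.49 log units; beyond the scatter).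

Compound 4 `CCCCc1nc(C)c(CC(=O)N2CCC[C@H]2C(N)=O)c(=O)n1Cc1ccc(-c2ccccc2-c2nnn[nH]2)cc1` differs by carbamoyl in place of hydrogen on a saturated ring carbon, next to the ring nitrogen. Going by the values given here, no measured step adds a group at this place, so the evidence is indirect. The closest is a 3.1-fold higher number from compound 2 to compound 3 (0.49 log units; beyond the scatter), with pyrrolidin-1-yl in place of dimethylamino on a carbonyl carbon. The other change on the same side chain is a 3.7-fold lower number from compound 1 to compound 2 (0.56 log units; beyond the scatter). Both are modest, so a step of at most modest size is plausible in this assay, and the data fix no direction. The expected result is a 1.3-fold higher number from compound 3 to compound 4 (0.10 log units; within the scatter), with no shift beyond the scatter as the central expectation. For compound 4 the estimate is 0.07 mg/kg, with an expected range of 0.02 mg/kg to 0.25 mg/kg.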

Compound 4, dose for half-maximal effect: 0.023 mg/kg
For compound 4 the middle estimate is 3.0-fold (0.48 log units) above the measured one; the measured number falls inside the stated range.
By their numbers in this assay, from the lowest: compounds 2 and 4 (each within the scatter of the next); then compounds 3 and 1 (each within the scatter of the next).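

Going by these compounds alone, this is the first measured step that adds a group on a saturated ring carbon next to the ring nitrogen: carbamoyl in place of hydrogen gives a 2.4-fold lower number from compound 3 to compound 4 (0.39 log units; beyond the scatter) in this assay, so the pyrrolidin-1-yl amide accepts a substituent at this place without the number rising. Against the dimethylamino amide, the 2-carbamoylpyrrolidin-1-yl amide shows a 1.3-fold higher number from compound 2 to compound 4 (0.11 log units; within the scatter) and thus stands level with it, whereas the unsubstituted pyrrolidin-1-yl amide had stood apart from it. The change to the whole side chain from the ester gives a 2.9-fold lower number from compound 1 to compound 4 (0.46 log units; beyond the scatter) and is a larger step than the one printed for the unsubstituted pyrrolidin-1-yl amide, which stayed within the scatter of the ester.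

Open, on these data alone, is how a carboxylic acid, an aminomethyl group or a longer chain at this ring carbon would read, and whether the opposite configuration there would match compound 4. Nothing measured beyond these doses bears on the reason for the step.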